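Trimming the Chain: From Compound 2 to Compound 3

A few compounds are considered here, and "the series" means these few. Any claim that something is new, unique, unknown or untested is made for them only; others in the source may bear on it.

Measured compounds:
Compound 1 `CCc1cn([C@H]2C[C@@H]3OP(=O)(O)OC[C@H]3O2)c(=O)[nH]c1=O`: > 500 ug/mL
Compound 2 `CCCCCCCCc1cn([C@H]2C[C@@H]3OP(=O)(O)OC[C@H]3O2)c(=O)[nH]c1=O`: 193 ug/mL

In a functional assay on L1210 cells (Mus musculus) (a lower number here means a stronger inhibitor, a higher number a weaker inhibitor), compound 1 reaches only a limit, not a number: the limit of > 500 ug/mL in this assay, at which 1 of the 2 values shown sits. Among the measured compounds shown here, compound 2 gives the only true number here. For the measured compounds named here, the single measured step is an at least 2.5-fold lower number from compound 1 to compound 2 (0.41 log units; beyond the scatter). Compound 3 `CCCCCCc1cn([C@H]2C[C@@H]3OP(=O)(O)OC[C@H]3O2)c(=O)[nH]c1=O` differs from compound 2 by hydrogen in place of ethyl on a saturated chain carbon, six bonds along the chain from an aromatic carbon, so its chain length falls between those of compound 1 and compound 2. Since lengthening the chain lowered the number, shortening it is expected to raise the number modestly, estimated as a 1.6-fold higher number from compound 2 to compound 3 (0.19 log units; within the scatter). Compound 3 is therefore expected to give about 300 ug/mL, in a range from 160 ug/mL to 550 ug/mL.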

Compound 3, concentration for 50% inhibition: > 500 ug/mL
Compound 3: no number, only a limit; the forecaster's own chance of this, stated with the estimate: 30%; middle value at least 1.6-fold (0.22 log units) away from the limit.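

In this assay, hydrogen in place of ethyl, six bonds along the chain from an aromatic carbon, gives an at least 2.5-fold higher number from compound 2 to compound 3 (0.41 log units; beyond the scatter), so the outer part of the chain counts here, which compound 1 and compound 2 alone could not show. Compound 3 gives only a limit, > 500 ug/mL. The step between compound 1 and compound 3 cannot be read, and the series now stands mostly at a limit: the limit of > 500 ug/mL in this assay, at which 2 of the 3 values shown sit.

On these data alone, whether a longer chain would lower the number further stays open. So does the effect of an amine or a carboxylic acid on the chain.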